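Removing a Trifluoromethyl Group From a Weak Cytotoxic Amide

The source may report more compounds than this note shows. Statements on the series, on what has been measured and on what is new or still open speak of the compounds shown alone.

For the measured compounds named here, compound 3 `O=C(Nc1ccc(Oc2ccnc3[nH]ccc23)cc1)c1cc(-c2ccc(C(F)(F)F)cc2)ccn1` is the one member of this small set that gives a number in a functional assay on PC-3 cells (Homo sapiens) for cytotoxicity, read by MTT assay, with a stated time of 72 h; on this read-out higher numbers stand for weaker inhibition and lower numbers for stronger inhibition: compound 3 gives 14200 nM. Compound 1 `O=C(Nc1ccc(Oc2ccnc3[nH]ccc23)cc1)c1ccc(-c2ccc(Cl)cc2)cn1` reaches only a limit of the assay, > 10000 nM. Compound 2 `Cc1ccc(-c2ccc(C(=O)Nc3ccc(Oc4ccnc5[nH]ccc45)cc3)nc2)cc1` likewise stops at a limit, > 10000 nM. The step that the two limits leave unreadable from compound 1 to compound 2 is unreadable because both of its ends sit at the limit of > 10000 nM in this assay, at which 2 of the 3 values shown sit, so compound 3 stands alone as the sole measured point, and it stands far up the scale.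

Compound 4 `O=C(Nc1ccc(Oc2ccnc3[nH]ccc23)cc1)c1cc(-c2ccccc2)ccn1` differs from compound 3 by hydrogen in place of trifluoromethyl on an aromatic carbon. Going by the values given here, none of the measured steps touches this change: the single step between measured compounds concerns a methyl and a chloro at a different position and cannot be sized. With nothing to carry over, compound 4 is expected to remain near compound 3, and the expected step of a 1.1-fold higher number from compound 3 to compound 4 (0.02 log units; within the scatter) lies within the scatter. For compound 4 the estimate is 15000 nM, with a range from 5000 nM to 45000 nM, and a fair chance that only a limit is reported.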

Compound 4, half-maximal inhibitory concentration: 3270 nM
The estimate for compound 4 lay 4.6-fold (0.66 log units) above the measured number; the measured number lies below the stated range.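

In this assay, for the compounds shown here, the change gives a 4.3-fold lower number from compound 3 to compound 4 (0.64 log units; beyond the scatter), the first step in this set whose size can be read. It places a measurable effect on an aromatic carbon of a six-membered aromatic ring of carbon only, para to a large group, where going from 4-(trifluoromethyl)phenyl to phenyl lowers the number rather than raising it, so trifluoromethyl is not required there for the cytotoxicity seen in compound 3. Nothing measured here gives a reason for this step.

On these data alone, what an amine, a carboxylic acid or a methoxy group on that same carbon would give remains open. The step between compound 1 and compound 2 cannot be read, so the chloro and methyl groups offer no size to set against this change.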